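Chain extension of the amine cap in the chloromethyl ketone series

This account rests on a few compounds, and the source may have more. Where it says the series, first, only, none or still open, it means among the compounds named here.

Three compounds of the series carry a measured number. Compound 1 `CC(C)=CCC/C(C)=C/CC/C(C)=C/CSC[C@H](NC(=O)OC(C)(C)C)C(=O)C=[N+]=[N-]` gives 49800 nM in a functional assay on NALM-6 cells (Homo sapiens); a higher number here means a weaker inhibitor, a lower number a stronger inhibitor. Compound 2 `CC(=O)N[C@@H](CSC/C=C(\C)CC/C=C(\C)CCC=C(C)C)C(=O)CCl` gives 3000 nM in this assay, and compound 3 `CC(C)=CCC/C(C)=C/CC/C(C)=C/CSC[C@H](NC(=O)OC(C)(C)C)C(=O)CCl` gives 10700 nM. Compound 3 thus holds the second highest of the three numbers, with compound 2 nearest and compound 1 furthest away. The two steps recorded around compound 3 are a 4.7-fold lower number from compound 1 to compound 3 (0.67 log units; beyond the scatter) and a 3.6-fold higher number from compound 2 to compound 3 (0.55 log units; beyond the scatter).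

Compound 4 `CC(C)=CCC/C(C)=C/CC/C(C)=C/CSC[C@H](NC(=O)CNC(=O)OC(C)(C)C)C(=O)CCl` has not been measured. Its difference from compound 3 is ((tert-butoxycarbonyl)amino)methyl in place of tert-butoxy on a carbonyl carbon. Within the data shown here, of the measured steps, only the one from compound 2 to compound 3 touches the same carbonyl carbon: there, tert-butoxy in place of methyl moved the number up by a modest amount. The present change enlarges the same group further rather than shrinking it back, so no guidance exists in the recorded steps for a group of this size, and the expected step in this assay is set near zero with wide uncertainty. The number for compound 4 is estimated at 9000 nM, within 2500 nM to 30000 nM, which corresponds to an expected step of a 1.2-fold lower number from compound 3 to compound 4 (0.08 log units; within the scatter).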

Compound 4, half-maximal inhibitory concentration: 12900 nM
Beside the measured number, compound 4's estimate is 1.4-fold (0.16 log units) below it; the range from low to high includes it.
By their numbers in this assay, from the lowest: compound 2; then compounds 3 and 4 (each within the scatter of the next); then compound 1.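

In this assay, among these compounds, the carbonyl carbon whose other neighbours are the amide-type nitrogen tolerates a bigger group than the earlier compounds showed: ((tert-butoxycarbonyl)amino)methyl in place of tert-butoxy, with a hydrogen-bond donor added, gives a 1.2-fold higher number from compound 3 to compound 4 (0.08 log units; within the scatter). Measured from the methyl cap of compound 2, (tert-butoxycarbonyl)amino in place of hydrogen gives a 4.3-fold higher number from compound 2 to compound 4 (0.63 log units; beyond the scatter), a modest step in the same direction as a 3.6-fold higher number from compound 2 to compound 3 (0.55 log units; beyond the scatter), so among these three chloromethyl ketones both larger caps give higher numbers than methyl. No measurement on hand bears on the reason for these numbers.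

The compounds shown leave open whether the higher numbers follow from the tert-butoxycarbonyl unit that compounds 3 and 4 share, or from cap size more generally, which a free amine in place of the (tert-butoxycarbonyl)amino group or a plain ethyl cap would help separate. Also open, going by these compounds, is whether a carboxylic acid or a longer chain at this carbonyl carbon would stay level with compound 3 and compound 4 or move towards compound 2.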